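The compounds below may be only part of what the source reports. "The series", "measured", "known", "first", "only" and "open" are said of these compounds alone.

Of the compounds shown here, two have been measured so far in a functional assay on HepG2 cells (Homo sapiens) for inhibition, read by MTT assay, with a stated time of 24 h; a higher number here means a weaker inhibitor, a lower number a stronger inhibitor. Compound 1 `COc1ccc(Cc2nc(-c3cc(Br)c(OCCCN(C)C)c(Br)c3)c[nH]c2=O)cc1Br` gives 16700 nM in this assay, which is the lowest of the two numbers. Compound 2 `COc1ccc(Cc2nc(-c3cc(Br)c(OCCCN(C)C)c(Br)c3)cnc2Cl)cc1Br`, whose core carries a chlorine-bearing ring in place of the ring with the amide hydrogen, gives 63200 nM in this assay, a higher number, and the gap between the two lies beyond the usual scatter, so compound 2 is the weaker inhibitor of the pair.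

Compound 3 `CNCCCOc1c(Br)cc(-c2c[nH]c(=O)c(Cc3ccc(OC)c(Br)c3)n2)cc1Br` has not yet been measured. It differs from compound 1 only by hydrogen in place of methyl on an amine nitrogen, that is, dimethylamino becomes methylamino on the chain that hangs from the ring with two bromines. Among the compounds with values here, nothing among the measured pair shows what such a change does here. The step of a 1.2-fold higher number from compound 1 to compound 3 (0.08 log units; within the scatter) is expected to be small, most likely no larger than the scatter itself, in either direction. Compound 3 is therefore estimated to give about 20000 nM in this assay, within a range from 7000 nM to 60000 nM.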

Compound 3, half-maximal inhibitory concentration: 53300 nM
Compound 3: the middle estimate sits 2.7-fold (0.43 log units) below what was measured; low and high end bracket the measured number.
By their numbers in this assay, from the lowest: compound 1; then compounds 3 and 2 (each within the scatter of the next).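

Within the data shown here, this result gives the first look at the amine nitrogen on the chain, and it shows that the position matters in this assay. Swapping one methyl for hydrogen, so that dimethylamino becomes methylamino, gives a 3.2-fold higher number from compound 1 to compound 3 (0.50 log units; beyond the scatter) and so a weaker inhibitor; the step is modest but lies beyond the scatter, even though only one carbon leaves. No measurement at hand explains this loss.

From the compounds shown here alone, it remains open what happens at this nitrogen with a plain amino group, which has no methyl at all, or with larger groups such as diethylamino or morpholine. A single step also cannot show whether a longer chain would respond in the same way, or whether the same change on the chlorine-bearing compound 2 would give a similar step.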